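Changing the amine at the end of the side chain

A few compounds are considered here, and "the series" means these few. Any claim that something is new, unique, unknown or untested is made for them only; others in the source may bear on it.

Compound 1 `CC(C)=CCc1cc(C(=O)Nc2cc3ccc(OCCCN4CCCC4)c(C)c3oc2=O)ccc1O` gives 720 nM in a functional assay on SK-BR-3 cells (Homo sapiens) for antiproliferative activity; a higher number here means a weaker inhibitor, a lower number a stronger inhibitor.
Compound 2 `CC(C)=CCc1cc(C(=O)Nc2cc3ccc(OCCCNc4ccccc4)c(C)c3oc2=O)ccc1O` reaches only the limit of this assay, > 50000 nM.
Compound 3 `CC(C)=CCc1cc(C(=O)Nc2cc3ccc(OCCCN[C@H](C)c4ccccc4)c(C)c3oc2=O)ccc1O` gives 1000 nM.

Compound 1 has the lowest of the two numbers; compound 3 differs from it by a 1.4-fold higher number from compound 1 to compound 3 (0.14 log units; within the scatter). Compound 4 `CC(C)=CCc1cc(C(=O)Nc2cc3ccc(OCCCN(C)Cc4ccccc4)c(C)c3oc2=O)ccc1O` differs from compound 1 by benzyl(methyl)amino in place of pyrrolidin-1-yl on a saturated chain carbon, three bonds along the chain from an oxygen on an aromatic ring. Two measured steps speak to this change: an at least 69-fold higher number from compound 1 to compound 2 (1.84 log units; beyond the scatter) and a 1.4-fold higher number from compound 1 to compound 3 (0.14 log units; within the scatter), with an at least 50-fold lower number from compound 2 to compound 3 (1.69 log units; beyond the scatter) between them. The large loss appears only with anilino, where phenyl sits directly on the amine nitrogen; benzyl(methyl)amino instead resembles (1-phenylethyl)amino in compound 3. The step is therefore expected to be a 1.4-fold higher number from compound 1 to compound 4 (0.14 log units; within the scatter), not beyond the scatter. Compound 4 is estimated at 1000 nM, between 300 nM and 4000 nM.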

Compound 4, half-maximal inhibitory concentration: 10700 nM
Beside the measured number, compound 4's estimate is 11-fold (1.03 log units) below it; the whole stated range lies below it.
By their numbers in this assay, from the lowest: compounds 1 and 3 (each within the scatter of the next); then compound 4. At a limit, above all of these: compound 2.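

Benzyl(methyl)amino also brings a large loss at the end of the chain, with a 15-fold higher number from compound 1 to compound 4 (1.17 log units; beyond the scatter) and an 11-fold higher number from compound 3 to compound 4 (1.03 log units; beyond the scatter), so such a loss is not confined to anilino, and two amines that both carry a phenyl ring through a carbon can differ widely. Compound 4 still keeps measurable activity, with an at least 4.6-fold lower number from compound 2 to compound 4 (0.66 log units; beyond the scatter). That step starts from a limit, not a number: the limit of > 50000 nM in this assay, at which 1 of the 4 values shown sits.

The compounds shown do not separate the effect of the methyl on the amine nitrogen in compound 4 from that of its benzyl group. As far as these compounds go, whether piperidine, morpholine or a longer chain would match compound 1 remains open.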